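The compounds below may be only part of what the source reports. "The series", "measured", "known", "first", "only" and "open" are said of these compounds alone.

Working notes on the series. In a functional assay on HepG2 cells (Homo sapiens) for cytotoxicity (on this read-out lower numbers stand for stronger inhibition and higher numbers for weaker inhibition), compound 2 `O=S(=O)(N/C(=N\O)Nc1ccc(Cl)cc1)c1ccccc1` gives 54 ug/mL and compound 1 `Cc1ccc(S(=O)(=O)N/C(=N\O)Nc2ccc(Cl)cc2)cc1` gives 49 ug/mL, so these two stand level within the scatter. For the measured compounds named here, compound 3 `O=S(=O)(N/C(=N\O)Nc1ccc(Cl)cc1)c1ccc(-c2cccs2)cn1` gives 121 ug/mL, a higher number than either, which leaves compound 2 with compound 1 under compound 3 on the numbers so far.

The next step leads to compound 4 `N#Cc1c(Cl)cccc1Oc1ccc(S(=O)(=O)N/C(=N\O)Nc2ccc(Cl)cc2)cc1`, and the structural change is 3-chloro-2-cyanophenoxy in place of hydrogen on an aromatic carbon. Going by the values given here, only one measured step changes a single place, a hydrogen in place of methyl on an aromatic carbon: a 1.1-fold higher number from compound 1 to compound 2 (0.04 log units; within the scatter). That swap is far smaller than the group entering here, so it offers only weak guidance. Compound 3 differs from compound 2 in more than one place, so compound 3 at 121 ug/mL is no more than a loose hint towards a higher number.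

In this assay, a modest rise is therefore expected, with no firm step beyond the scatter. The estimated step is a 1.5-fold higher number from compound 2 to compound 4 (0.17 log units; within the scatter). For compound 4 the expected value is 80 ug/mL, with an estimated range of 30 ug/mL to 200 ug/mL.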

Compound 4, half-maximal inhibitory concentration: > 300 ug/mL
Compound 4 was reported as a limit; the forecaster's own chance of this, stated with the estimate: 15%; middle value at least 3.7-fold (0.57 log units) away from the limit.
By their numbers in this assay, from the lowest: compounds 1 and 2 (each within the scatter of the next); then compound 3. At a limit, above all of these: compound 4.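

In this assay this aromatic carbon, para to a large group, turns out to be sensitive to what it carries: hydrogen and methyl stood level there, whereas 3-chloro-2-cyanophenoxy in place of hydrogen gives an at least 5.5-fold higher number from compound 2 to compound 4 (0.74 log units; beyond the scatter). Set against methyl, the same group gives an at least 6.1-fold higher number from compound 1 to compound 4 (0.78 log units; beyond the scatter), so the step lies beyond the scatter from either small substituent, towards weaker inhibition. Compound 4 is a limit rather than a number, so both steps are lower bounds and their full size stays unknown: the limit of > 300 ug/mL in this assay, at which 1 of the 4 values shown sits.

Still open, on these data alone, is which part of the entering group goes with the higher number, since plain phenoxy would separate the ring from its chloro and nitrile substituents. As far as these compounds go, how a smaller group such as methoxy or an amine would read at this carbon also stays open.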